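A Small Change to a Fluorophenyl Side Chain

This account rests on a few compounds, and the source may have more. Where it says the series, first, only, none or still open, it means among the compounds named here.

In a functional assay on UACC-62 cells (Homo sapiens) for inhibition, read by sulforhodamine B assay, with a stated time of 48 h (a lower number here means a stronger inhibitor, a higher number a weaker inhibitor), compound 1 `CN1CCCN(CCNc2nccc(-c3c(-c4cccc(O)c4)nc4sccn34)n2)S1(=O)=O` gives 58 nM while compound 2 `O=S(=O)(NCCCNc1nccc(-c2c(-c3cccc(O)c3)nc3sccn23)n1)c1cccc(F)c1` gives 750 nM as the higher of the two numbers. In compound 3 `O=S(=O)(NCCNc1nccc(-c2c(-c3cccc(O)c3)nc3sccn23)n1)c1ccc(F)cc1` ((4-fluorophenyl)sulfonyl)amino stands in place of (((3-fluorophenyl)sulfonyl)amino)methyl ((4-fluorophenyl)sulfonyl)amino in place of (((3-fluorophenyl)sulfonyl)amino)methyl on a saturated chain carbon, two bonds along the chain from a nitrogen on an aromatic ring on a saturated chain carbon. Going by the values given here, the only measured step of a 13-fold higher number from compound 1 to compound 2 (1.11 log units; beyond the scatter) is large, but it swapped a non-aromatic ring for an aromatic one, and here an aromatic ring stays on both sides, so it offers little guidance. The estimated step of a 1.5-fold lower number from compound 2 to compound 3 (0.18 log units; within the scatter) therefore stays within the usual scatter. In this assay compound 3 is expected near 500 nM with 150 nM to 1600 nM as the estimated range.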

Compound 3, half-maximal inhibitory concentration: 270 nM
Compound 3: middle estimate off by 1.9-fold (0.27 log units), on the high side; the range from low to high includes it.
By their numbers in this assay, from the lowest: compound 1; then compound 3; then compound 2.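

In this assay, this position responds even when an aromatic ring stays on both sides: the swap gives a 2.8-fold lower number from compound 2 to compound 3 (0.44 log units; beyond the scatter) and so moves the number beyond the scatter. The new group still falls short of the non-aromatic ring group, with a 4.7-fold higher number from compound 1 to compound 3 (0.67 log units; beyond the scatter) on that comparison. Nothing available here explains either step.

On these data alone, the step to compound 3 removes the methyl link and also changes 3-fluorophenyl to 4-fluorophenyl, so the share of each change remains unknown. As far as these compounds go, how a plain phenylsulfonyl group without fluorine, or an amine, would behave here also stays open.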